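Swapping Methyl for Trifluoromethyl on Compound 3

The compounds below may be only part of what the source reports. "The series", "measured", "known", "first", "only" and "open" are said of these compounds alone.

In a functional assay on SMMC-7721 cells (Homo sapiens) for cytotoxicity, read by MTT assay, with a stated time of 24 h (a lower number here means a stronger inhibitor, a higher number a weaker inhibitor), compound 1 (`O=C1/C(=C/c2cccnc2)CN(S(=O)(=O)c2ccc(C(F)(F)F)cc2)C/C1=C\c1ccccc1F`) gives 7900 nM and compound 2 (`O=C1/C(=C/c2cccnc2)CN(S(=O)(=O)c2ccccc2)C/C1=C\c1ccccc1C(F)(F)F`) gives 10900 nM while compound 3 (`Cc1ccc(S(=O)(=O)N2C/C(=C\c3cccnc3)C(=O)/C(=C/c3ccccc3C(F)(F)F)C2)cc1`) gives 6700 nM which lies within the scatter of both.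

Compound 4 (`O=C1/C(=C/c2cccnc2)CN(S(=O)(=O)c2ccc(C(F)(F)F)cc2)C/C1=C\c1ccccc1C(F)(F)F`) carries trifluoromethyl in place of methyl on an aromatic carbon. Going by the values given here, the one measured step at that carbon, methyl in place of hydrogen, shows a 1.6-fold lower number from compound 2 to compound 3 (0.21 log units; within the scatter) and so offers no sign of a large effect there. Compound 1 already holds the 4-(trifluoromethyl)phenyl group and gives 7900 nM in the same range. No change beyond the scatter is expected in this assay and the estimated step is a 1.0-fold higher number from compound 3 to compound 4 (0.02 log units; within the scatter) in size. Compound 4 is estimated at 7000 nM with a range from 3500 nM to 14000 nM around it.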

Compound 4, half-maximal inhibitory concentration: 1730 nM
Compound 4: the middle estimate sits 4.0-fold (0.61 log units) above what was measured; the measured number lies below the stated range.
By their numbers in this assay, from the lowest: compound 4; then compounds 3, 1 and 2 (each within the scatter of the next).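

In this assay this carbon does respond to the group it carries: trifluoromethyl in place of methyl gives a 3.9-fold lower number from compound 3 to compound 4 (0.59 log units; beyond the scatter) and trifluoromethyl in place of hydrogen gives a 6.3-fold lower number from compound 2 to compound 4 (0.80 log units; beyond the scatter) while methyl in place of hydrogen stayed within the scatter. The 4-(trifluoromethyl)phenyl group does not set the number alone, since trifluoromethyl in place of fluoro on a different aromatic carbon gives a 4.6-fold lower number from compound 1 to compound 4 (0.66 log units; beyond the scatter) with that group present in both compounds.

On these data alone, whether an amine or a carboxylic acid at this carbon would lower the number as well remains open. No measurement shown here explains the lower number of compound 4.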